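The source may hold more compounds than are shown below. What is called first, only, known or untested is meant among the compounds shown, and "the series" means these compounds.

In a functional assay on HeLa cells (Homo sapiens) for antiproliferative activity, read by MTT assay, with a stated time of 48 h (a higher number here means a weaker inhibitor, a lower number a stronger inhibitor), compound 1 (`COc1ccc(C(=O)c2ccc3c(c2)C=CC(C)(C)O3)c(NC(=O)CO)c1`) gives 240 nM and stands in the middle of the three measured compounds. Compound 2 (`COc1ccc(C(=O)c2ccc(OC)c3c2C=CC(C)(C)O3)c(NC(=O)CN)c1`) gives 100 nM on the lower side and compound 3 (`CNCC(=O)Nc1cc(OC)ccc1C(=O)c1ccc(OC)c2c1OC(C)(C)C=C2`) gives 870 nM on the higher side, and both gaps to compound 1 lie beyond the scatter. Compound 4 (`CNCC(=O)Nc1cc(OC)ccc1C(=O)c1ccc2c(c1)C=CC(C)(C)O2`) keeps the core of compound 1 and has not yet been measured. It carries methylamino in place of hydroxy on a saturated chain carbon bound to a carbonyl carbon. For the measured compounds named here, no measured pair isolates this change. Compound 3 also carries methylamino on that chain carbon, though on another core, and its 870 nM is the highest number of the set, so a move to a higher number is expected. In this assay the expected change is a moderate rise, estimated as a 2.1-fold higher number from compound 1 to compound 4 (0.32 log units; beyond the scatter) and resting on that single comparison. For compound 4 the estimated value is 500 nM with an expected range of 170 nM to 1300 nM around it.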

Compound 4, half-maximal inhibitory concentration: 970 nM
For compound 4 the middle estimate is 1.9-fold (0.29 log units) below the measured one, and the stated range covers the measured number.
By their numbers in this assay, from the lowest: compound 2; then compound 1; then compounds 3 and 4 (each within the scatter of the next).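

In this assay, for the compounds shown here, this step gives the first direct reading of the position: with the rest of the structure held constant, methylamino in place of hydroxy on a saturated chain carbon bound to a carbonyl carbon gives a 4.0-fold higher number from compound 1 to compound 4 (0.61 log units; beyond the scatter). The hydrogen-bond donor and acceptor counts of the leaving and entering groups are the same, so the rise comes without any change in those counts. Nothing at hand accounts for the step, and its cause remains unassigned.

A plain amino group on this same core would help separate the part played by nitrogen replacing oxygen from that of the added methyl. Going by these compounds, how a carboxylic acid, a dimethylamino group or a longer chain at this carbon would read also remains open.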